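Lengthening One Ester on Compound 1

A few compounds are considered here, and "the series" means these few. Any claim that something is new, unique, unknown or untested is made for them only; others in the source may bear on it.

Among the measured compounds shown here, in a functional assay on U-251 cells (Homo sapiens) for antiproliferative activity, read by sulforhodamine B assay, with a stated time of 72 h (on this read-out lower numbers stand for stronger inhibition and higher numbers for weaker inhibition), compound 1 (`COc1cc(/C=C/COC(C)=O)ccc1OC(C)=O`) gives 9710 nM and holds the lowest of the three numbers measured so far. Compound 3 (`CCCC(=O)OC/C=C/c1ccc(OC(C)=O)c(OC)c1`) reads 33300 nM and compound 2 (`CCC(=O)OC/C=C/c1ccc(OC(=O)CC)c(OC)c1`) reads 52600 nM and both numbers lie beyond the scatter on the weaker side of compound 1.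

Compound 4 (`CCCC(=O)Oc1ccc(/C=C/COC(C)=O)cc1OC`) has not yet been measured. It departs from compound 1 by ethyl in place of hydrogen on a saturated chain carbon bound to a carbonyl carbon with ethyl in place of hydrogen on a saturated chain carbon bound to a carbonyl carbon, which turns acetoxy to (propylcarbonyl)oxy. For the measured compounds named here, the same kind of change, made at the other acetoxy, gave a 3.4-fold higher number from compound 1 to compound 3 (0.54 log units; beyond the scatter) in this assay and this is the one measured step that bears on it. Going by the values given here, compound 2 differs from compound 1 in more than one place, so it offers no single step. One step taken at a different place is a thin guide. A modest rise toward weaker inhibition is therefore expected, perhaps slightly smaller than that step, and the range is kept wide. The expected change is a 2.6-fold higher number from compound 1 to compound 4 (0.41 log units; beyond the scatter) on this estimate. For compound 4 the estimated value is 25000 nM with an expected range from 10000 nM to 60000 nM in this assay.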

Compound 4, half-maximal inhibitory concentration: 45700 nM
Compound 4: the middle estimate sits 1.8-fold (0.26 log units) below what was measured, within the range that was stated.
By their numbers in this assay, from the lowest: compound 1; then compounds 3, 4 and 2 (each within the scatter of the next).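

In this assay, turning acetoxy to (propylcarbonyl)oxy at this ester gives a 4.7-fold higher number from compound 1 to compound 4 (0.67 log units; beyond the scatter), and the same change at the other acetoxy gave a 3.4-fold higher number from compound 1 to compound 3 (0.54 log units; beyond the scatter), so the change now reads toward weaker inhibition at both esters and not at one alone. Among the compounds shown, compound 1, which carries acetoxy at both places, keeps the lowest number, and each compound with a lengthened ester stands beyond the scatter on the weaker side of it. No measurement among those shown accounts for this shift.

Going by these compounds, whether a still longer chain, such as a hexanoyl ester, would carry the trend further at this position remains open, as does what the smaller formyl ester would do in place of the acetoxy. Also open, on these data alone, is how a free hydroxyl, an amide or a carboxylic acid at this place would read against compound 1. A compound with (propylcarbonyl)oxy at both esters has not been measured.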